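The compounds below may be only part of what the source reports. "The series", "measured", "known", "first", "only" and "open" are said of these compounds alone.

Compound 1 `O=C(Nc1cccc(-n2cc(-c3ccncc3)c(-c3ccc(Cl)c(O)c3)n2)c1)Nc1cccc(C(F)(F)F)c1`: > 32500 nM (a limit of the assay, not a number)
Compound 2 `COc1cc(-c2nn(-c3cccc(NC(=O)Nc4cc(C(F)(F)F)cc(C(F)(F)F)c4)c3)cc2-c2ccncc2)ccc1Cl`: 1280 nM
Compound 3 `COc1cc(-c2nn(-c3cccc(NC(=O)Nc4cccc(C(F)(F)F)c4)c3)cc2-c2ccncc2)ccc1Cl`: 3210 nM

Of the compounds shown here, three have been measured in a functional assay on UO-31 cells (Homo sapiens) for inhibition, read by sulforhodamine B assay, with a stated time of 48 h; a higher number here means a weaker inhibitor of growth, a lower number a stronger inhibitor of growth. Compound 1 gives > 32500 nM, which is a limit of the assay rather than a measured number. Compound 2 gives 1280 nM in this assay. Compound 3 gives 3210 nM in this assay. Of the two numbers, compound 2 stands lowest, with compound 3 nearest at a 2.5-fold higher number from compound 2 to compound 3 (0.40 log units; beyond the scatter).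

Compound 4 `O=C(Nc1cccc(-n2cc(-c3ccncc3)c(-c3ccc(Cl)c(O)c3)n2)c1)Nc1cc(C(F)(F)F)cc(C(F)(F)F)c1` has not yet been measured. It differs from compound 2 in one place: hydrogen in place of methyl on an oxygen on an aromatic ring. Among the compounds with values here, the measured step that bears on this is the one from compound 1 to compound 3, which runs the opposite way, methyl in place of hydrogen on the same oxygen, and gave an at least 10-fold lower number from compound 1 to compound 3 (1.00 log units; beyond the scatter). Turned around, a step of at least that size upward is expected in this assay for compound 4. Such a step could reach the limit seen for compound 1, namely (the limit of > 32500 nM in this assay, at which 1 of the 3 values shown sits). Compound 4 is therefore expected to give 20000 nM in this assay, between 6000 nM and 65000 nM, which is expected to amount to a 16-fold higher number from compound 2 to compound 4 (1.19 log units; beyond the scatter).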

Compound 4, concentration for total growth inhibition: 1900 nM
For compound 4 the middle estimate is 11-fold (1.02 log units) above the measured one; the whole stated range lies above it.
By their numbers in this assay, from the lowest: compounds 2, 4 and 3 (each within the scatter of the next, the first and the last beyond it). At a limit, above all of these: compound 1.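

In this assay, hydroxy in place of methoxy makes no clear difference once the second trifluoromethyl is present, with a 1.5-fold higher number from compound 2 to compound 4 (0.17 log units; within the scatter). A free hydroxy on this ring is therefore not enough on its own to lose growth inhibition, and the methyl on that oxygen matters only on the core with a single trifluoromethyl, as the same change on two cores shows: the same change on two cores in this assay, an at least 10-fold lower number (1.00 log units; beyond the scatter) from compound 1 to compound 3 and a 1.5-fold lower number (0.17 log units; within the scatter) from compound 4 to compound 2, at least 6.8-fold (0.83 log units) apart, beyond the scatter of two such steps. Read the other way, adding the second trifluoromethyl counts for far more with hydroxy than with methoxy, with an at least 17-fold lower number from compound 1 to compound 4 (1.23 log units; beyond the scatter), a step that starts from a limit of the assay and not from a number: the same change on two cores in this assay, a 2.5-fold higher number (0.40 log units; beyond the scatter) from compound 2 to compound 3 and an at least 17-fold higher number (1.23 log units; beyond the scatter) from compound 4 to compound 1, at least 6.8-fold (0.83 log units) apart, beyond the scatter of two such steps.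

From the compounds shown here alone, it remains open whether this dependence holds for other groups at that position, such as an ethoxy group or an amine in place of the hydroxy. These compounds also do not explain why the two changes depend on each other.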